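Branched cyclohexyl tail in place of a straight chain

This account rests on a few compounds, and the source may have more. Where it says the series, first, only, none or still open, it means among the compounds named here.

Three compounds have been measured in a functional assay on membranes from Sf9 cells for agonist activity at histamine H2 receptor (Homo sapiens), read by scintillation counting and GTPgammaS binding, with a stated time of 90 min; on this read-out higher numbers stand for an effect only at larger amounts of compound and lower numbers for an effect already at smaller amounts:
Compound 1 `Cc1ccc(CC(C)CNC(=O)/N=C(\N)NCCCc2sc(N)nc2C)cc1` gives 60.3 nM.
Compound 2 `CCCCCCNC(=O)/N=C(\N)NC1CCc2nc(N)sc2C1` gives 148 nM.
Compound 3 `CCCCCCNC(=O)/N=C(\N)NCCCc1sc(N)nc1C` gives 38.9 nM.

Compound 3 has the lowest number of the three. Its gap to compound 1 is within the scatter of repeated measurements, so the two cannot be told apart; its gap to compound 2, which carries a ring-fused core instead of the open chain, lies beyond the scatter, with compound 2 needing the larger amount.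

Compound 4 `Cc1nc(N)sc1CCCN/C(N)=N/C(=O)NCC(C)C1CCCCC1` has not been measured. It differs from compound 3 in one place: 1-cyclohexylethyl in place of pentyl on a saturated chain carbon bound to an amide-type nitrogen. The chain on the amide-type nitrogen thus keeps a similar length but gains a branch and a six-membered ring, a shape that compound 1 shares in part with its branched aryl-bearing chain, and compound 1 sits within the scatter of compound 3. For the measured compounds named here, no measured pair shows this exact change, so the expected step of a 1.3-fold higher number from compound 3 to compound 4 (0.11 log units; within the scatter) is small, with no clear direction beyond the scatter. Compound 4 is estimated at 50 nM, likely between 18 nM and 150 nM.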

Compound 4, half-maximal effective concentration: 21.9 nM
Estimate against measurement, compound 4: 2.3-fold (0.36 log units) above; measured number inside the range.
By their numbers in this assay, from the lowest: compounds 4, 3 and 1 (each within the scatter of the next, the first and the last beyond it); then compound 2.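

Putting 1-cyclohexylethyl in place of pentyl gives a 1.8-fold lower number from compound 3 to compound 4 (0.25 log units; within the scatter), so compound 3 and compound 4 cannot be told apart, and this position accepts a branch and a six-membered non-aromatic ring with no change that clears the scatter. Cyclohexyl in place of 4-methylbenzyl gives a 2.8-fold lower number from compound 1 to compound 4 (0.44 log units; beyond the scatter) and is the first step at this tail to lie beyond the scatter, though only a modest one. Nothing available explains either step.

From the compounds shown here alone, it remains open how a phenyl group in place of the cyclohexyl, or a longer chain carrying the same ring, would read at this position. Going by these compounds, it is also open whether the branch or the ring matters more, which a straight chain ending in cyclohexyl could help to separate.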